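The compounds below may be only part of what the source reports. "The series", "measured", "known", "first", "only" and "open" are said of these compounds alone.

Compound 1 `O=C(CN1CCN(c2nnc(Cc3ccccc3)c3ccccc23)CC1)Nc1ccc(F)c(C(F)(F)F)c1` is the weakest of the three compounds measured in a functional assay on HT-29 cells (Homo sapiens) for cytotoxicity, read by MTT assay, with a stated time of 72 h (a lower number here means a stronger inhibitor, a higher number a weaker inhibitor), where compound 1 gives 4590 nM. Compound 2 `O=C(CN1CCN(c2nnc(Cc3ccncc3)c3ccccc23)CC1)Nc1ccc(F)c(C(F)(F)F)c1` carries pyridin-4-yl in place of phenyl on a saturated chain carbon bound to an aromatic carbon, and in this assay compound 2 gives 1110 nM, a step of a 4.1-fold lower number from compound 1 to compound 2 (0.62 log units; beyond the scatter). Compound 3 `O=C(CN1CCN(c2nnc(Cc3ccncc3)c3ccccc23)CC1)Nc1ccc(F)c(Cl)c1` differs from compound 2 by chloro in place of trifluoromethyl on an aromatic carbon; in this assay compound 3 gives 880 nM, a step of a 1.3-fold lower number from compound 2 to compound 3 (0.10 log units; within the scatter).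

Compound 4 `O=C(CN1CCN(c2nnc(Cc3ccccc3)c3ccccc23)CC1)Nc1cccc(Br)c1` departs from compound 1 by 3-bromophenyl in place of 4-fluoro-3-(trifluoromethyl)phenyl on an amide-type nitrogen. Among the measured compounds shown here, the only measured step that touches the same part of the molecule is the one from compound 2 to compound 3, where chloro replaced trifluoromethyl on an aromatic carbon, and that step was a 1.3-fold lower number from compound 2 to compound 3 (0.10 log units; within the scatter). The step from compound 1 to compound 2 concerns a different part of the shared core and does not bear on this change. Nothing measured speaks to removing the fluoro or placing bromo there, so the expectation rests on that single small step.

Compound 4 is therefore expected to sit close to compound 1, with an estimated step of a 1.1-fold higher number from compound 1 to compound 4 (0.04 log units; within the scatter), and compound 4 is estimated at 5000 nM, within a range of 1500 nM to 16000 nM.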

Compound 4, half-maximal inhibitory concentration: 13400 nM
Beside the measured number, compound 4's estimate is 2.7-fold (0.43 log units) below it; measured number inside the range.
By their numbers in this assay, from the lowest: compounds 3 and 2 (each within the scatter of the next); then compound 1; then compound 4.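

In this assay, the group on the amide-type nitrogen proves able to shift the number beyond the scatter: replacing 4-fluoro-3-(trifluoromethyl)phenyl with 3-bromophenyl gives a 2.9-fold higher number from compound 1 to compound 4 (0.47 log units; beyond the scatter), whereas the earlier change on this aryl group, made on the pyridin-4-yl compounds, gave only a 1.3-fold lower number from compound 2 to compound 3 (0.10 log units; within the scatter). This step also runs in the opposite direction to the other change made from compound 1, a 4.1-fold lower number from compound 1 to compound 2 (0.62 log units; beyond the scatter), although it alters two things at once, with the fluoro gone and bromo standing where the trifluoromethyl stood, so the compounds cannot divide the step between those two parts. Nothing available explains why this aryl change raises the number in this assay.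

The compounds shown leave open whether the loss of the fluoro or the arrival of the bromo accounts for the step, and whether a methoxy or a nitrile in place of the bromo would move the number in the same direction. They also leave open whether pyridin-4-yl in place of phenyl would lower the number on the 3-bromophenyl amide as it did on compound 1.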